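The compounds below may be only part of what the source reports. "The series", "measured", "known", "first", "only" and "open" are said of these compounds alone.

Measured compounds in an assay for inhibition of Fatty-acid amide hydrolase 1 (Rattus norvegicus), using a Dixon plot; on this read-out higher numbers stand for weaker inhibition and lower numbers for stronger inhibition:
compound 1 `O=C(CCCCCCc1ccccc1)c1ncc(-c2ccc(CO)cn2)o1` gives 3.2 nM
compound 2 `O=CCCCCc1cnc(C(=O)CCCCCCc2ccccc2)o1` gives 14.6 nM
compound 3 `O=C(CCCCCCc1ccccc1)c1ncc(CCCCCO)o1` gives 10.1 nM

Compound 3 stands second highest of the three numbers. Its nearest neighbour is compound 2, where the step of a 1.4-fold lower number from compound 2 to compound 3 (0.16 log units; within the scatter) is within the scatter; its furthest is compound 1, where the step of a 3.2-fold higher number from compound 1 to compound 3 (0.50 log units; beyond the scatter) is beyond it. Replacing the 5-(hydroxymethyl)pyridin-2-yl of compound 1 with an open chain costs, as a 4.6-fold higher number from compound 1 to compound 2 (0.66 log units; beyond the scatter) also shows.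

Compound 4 `O=C(CCCCCCc1ccccc1)c1ncc(CCCCCCl)o1` is the next step from compound 3: chloro in place of hydroxy on a saturated chain carbon, five bonds along the chain from an aromatic carbon.

For the measured compounds named here, only one measured step bears on this: the change at the chain end from compound 2 to compound 3, a 1.4-fold lower number from compound 2 to compound 3 (0.16 log units; within the scatter), which stayed within the scatter. Going by the values given here, that the end group of the chain was exchanged there without a step beyond the scatter is the sole guide; no chloro compound has been measured in this assay. On that basis no step beyond the scatter is expected, a 1.2-fold higher number from compound 3 to compound 4 (0.07 log units; within the scatter).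

Compound 4 is therefore estimated at 12 nM, with a range from 5 nM to 30 nM.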

Compound 4, inhibition constant: 5.2 nM
Compound 4: middle estimate off by 2.3-fold (0.36 log units), on the high side, within the range that was stated.
By their numbers in this assay, from the lowest: compounds 1, 4, 3 and 2 (each within the scatter of the next, the first and the last beyond it).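

In this assay, chloro in place of hydroxy gives a 1.9-fold lower number from compound 3 to compound 4 (0.29 log units; within the scatter) on a saturated chain carbon, five bonds along the chain from an aromatic carbon, so a group counted with no hydrogen-bond donor or acceptor is accepted here without a step beyond the scatter. Against the formyl end of the shorter-named chain, the same compound gives a 2.8-fold lower number from compound 2 to compound 4 (0.45 log units; beyond the scatter) and this is the first end-group exchange on the chain to pass the scatter. An open chain in place of 5-(hydroxymethyl)pyridin-2-yl also need not cost: 5-chloropentyl gives a 1.6-fold higher number from compound 1 to compound 4 (0.21 log units; within the scatter). Compound 2 and compound 3 go against this, with steps beyond the scatter from compound 1. Nothing on hand accounts for these steps.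
On these data alone, whether an amine, a carboxylic acid or bromo at the chain end would hold the same level stays open. So does the effect of a longer chain carrying chloro.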